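The source may hold more compounds than are shown below. What is called first, only, known or untested is meant among the compounds shown, and "the series" means these compounds.

Three compounds were examined in a functional assay on the whole organism with Rattus norvegicus as the target, at a dose of 40 mg/kg by the intraperitoneal route; on this read-out lower numbers stand for less inhibition and higher numbers for more inhibition at the one dose given (going by the name of the read-out). Compound 1 `Cc1nc2c(OCCc3ccccc3)cccn2c1N` gives 56% in this assay. Compound 2 `Cc1nc2c(CCc3ccccc3)cccn2c1N` gives 47% in this assay. Compound 3 `Cc1nc2c(OCc3ccccc3)cccn2c1CN` gives 46% in this assay, the lowest of the three numbers, though its gap to compound 2 and its gap to compound 1 both lie within the usual scatter, so no order among the three can be claimed from these numbers.

Compound 4 `CNc1c(C)nc2c(OCc3ccccc3)cccn12` has not yet been measured in this assay. It differs from compound 3 in one place: methylamino in place of aminomethyl on an aromatic carbon. The two compounds hold the same atoms, joined differently. For the measured compounds named here, no measured pair in this set shares a change of this kind, so there is no precedent from which to read a step. The step of a number 2 percentage points higher from compound 3 to compound 4 (within the scatter) is expected to be small, not beyond the scatter, in no clear direction. Compound 4 is therefore estimated at 48% in this assay, within a range from 30% to 65%.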

Compound 4, a percentage reported as inhibition, in the whole organism at one dose (the size of the read-out at that dose, not a potency): 55%
Estimate against measurement, compound 4: 7 percentage points below; the measured number falls inside the stated range.
By their numbers in this assay, from the lowest: compounds 3, 2, 4 and 1 (each within the scatter of the next).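

In this assay, for the compounds shown here, the exchange of aminomethyl for methylamino on this aromatic carbon reads as a number 9 percentage points higher from compound 3 to compound 4 (within the scatter) and gives the only comparison so far between compounds that differ in one place. At this position, on the five-membered aromatic ring with 2 nitrogen, two groups with the same atoms joined differently therefore cannot be told apart at the one dose given. No measured evidence here bears on the reason for this result.

The compounds shown leave open whether a dimethylamino group, an aminoethyl chain or a carboxylic acid on this same carbon would stand apart from these two groups in this assay at all. They also leave open whether the exchange would read the same way with a phenylethoxy chain in place of the benzyloxy group on the shared core.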